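The source may report more compounds than this note shows. Statements on the series, on what has been measured and on what is new or still open speak of the compounds shown alone.

Measured in a functional assay on the whole organism (arterial blood) with Rattus norvegicus as the target; on this read-out lower numbers stand for an effect already at smaller amounts and higher numbers for an effect only at larger amounts of compound:
- Compound 1 `COC(=O)NC(CC(=O)N1CCC(Cn2c(C)nc3cnccc32)CC1)c1ccccc1`: 0.035 mg/kg
- Compound 2 `Cc1nc2cnccc2n1CC1CCN(C(=O)CC(C)c2ccccc2)CC1`: 0.033 mg/kg

In this assay compound 2 gives 0.033 mg/kg, which cannot be told apart from compound 1 at 0.035 mg/kg. Compound 3 `CCCC(CC(=O)N1CCC(Cn2c(C)nc3cnccc32)CC1)c1ccccc1` differs from compound 2 by ethyl in place of hydrogen on a saturated chain carbon, two bonds along the chain from an aromatic carbon. For the measured compounds named here, only one measured step bears on this change, a 1.1-fold lower number from compound 1 to compound 2 (0.03 log units; within the scatter), which also exchanges a group on a saturated chain carbon and stays within the scatter. Going by the values given here, one step is thin evidence, and no measured compound carries the longer chain, so no clear shift in this assay is expected. The expected change is small, a 1.2-fold higher number from compound 2 to compound 3 (0.08 log units; within the scatter). For compound 3 the estimate is 0.04 mg/kg, with an expected range of 0.015 mg/kg to 0.1 mg/kg.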

Compound 3, dose for 50% inhibition: 0.0079 mg/kg
Compound 3: middle estimate off by 5.1-fold (0.70 log units), on the high side; measured number below the stated range.
By their numbers in this assay, from the lowest: compound 3; then compounds 2 and 1 (each within the scatter of the next).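

Going from methyl in compound 2 to propyl in compound 3 gives the first change at this carbon that lies beyond the scatter in this assay (a 4.2-fold lower number from compound 2 to compound 3 (0.62 log units; beyond the scatter)). Propyl also stands apart from (methoxycarbonyl)amino (a 4.4-fold lower number from compound 1 to compound 3 (0.65 log units; beyond the scatter)), although methyl and (methoxycarbonyl)amino could not be told apart, so this position does respond to the group it carries. Nothing measured here explains this gain.
Going by these compounds, whether a butyl group or a still longer chain would lower the number further remains open, as does the effect of an amine or a carboxylic acid on this carbon.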